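The source may hold more compounds than are shown below. What is called first, only, known or untested is meant among the compounds shown, and "the series" means these compounds.

For the measured compounds named here, compound 1 `CC(=O)OCCOCN1c2ccccc2C(=O)N(Cc2ccccc2)S1(=O)=O` is examined in a functional assay on HEL cells (Homo sapiens) for cytotoxicity (a lower number here means that less compound is tolerated, a higher number that more compound is tolerated), where compound 1 gives 50 ug/mL, the only plain number recorded in this set. Compound 2 `CC(=O)OCCOCN1C(=O)c2ccccc2NS1(=O)=O` is reported in this assay only as a limit, > 50 ug/mL. Thus compound 1 stands alone as a measured figure, with one further value sitting at the limit of > 50 ug/mL in this assay, at which 1 of the 2 values shown sits. Compound 3 `O=C1c2ccccc2N(COCc2ccccc2)S(=O)(=O)N1Cc1ccccc1` differs from compound 1 by phenyl in place of acetoxymethyl on a saturated chain carbon bound to an oxygen on a saturated carbon. Going by the values given here, with no measured step to draw on, the account expects the change from compound 1 to compound 3 in this assay to be a 1.3-fold lower number from compound 1 to compound 3 (0.10 log units; within the scatter), a step of no more than modest size. Compound 3 is estimated at 40 ug/mL, with a range from 15 ug/mL to 100 ug/mL.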

Compound 3, minimum cytotoxic concentration: > 50 ug/mL
Compound 3 ended at the assay's limit; the forecaster's own chance of this, stated with the estimate: 20%; middle value at least 1.2-fold (0.09 log units) from the limit.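

Compound 3 gives > 50 ug/mL in this assay, which is a limit of the assay and not a number. With phenyl in place of acetoxymethyl on a saturated chain carbon bound to an oxygen on a saturated carbon, the result is a number no lower from compound 1 to compound 3 (the limit leaves the size open), so in this assay the acetoxymethyl group is not needed to keep the number from falling. The set now gathers at a single limit: the limit of > 50 ug/mL in this assay, at which 2 of the 3 values shown sit.

As far as these compounds go, how far compound 3 lies past that limit stays open, so the size of this step cannot be read. Whether an amine or a carboxylic acid at this place would lower the number is also left open.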